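The compounds below may be only part of what the source reports. "The series", "measured", "known", "first", "only" and "open" are said of these compounds alone.

Working notes on the series. Among the compounds with values here, the two measured members are compound 2 `O=c1[nH]c(=O)n(CCC(CO)CO)cc1C#CCc1ccccc1` and compound 1 `CCCCCCCCC#Cc1cn(CCC(COC(C)=O)COC(C)=O)c(=O)n(C(=O)c2ccccc2)c1=O`. In a functional assay on SW-620 cells (Homo sapiens) for antiproliferative activity, read by MTT assay, with a stated time of 72 h (on this read-out lower numbers stand for stronger inhibition and higher numbers for weaker inhibition), compound 2 gives 72400 nM, and in this assay compound 1 gives 65800 nM; the two numbers lie within the scatter of each other, so nothing separates them. Compound 3 `CC(C)(C)C#Cc1cn(CCC(CO)CO)c(=O)[nH]c1=O` follows from compound 2 by tert-butyl in place of benzyl on a triple-bonded carbon. Within the data shown here, no measured pair tells how such a change plays out here, so the expected step of a 1.1-fold higher number from compound 2 to compound 3 (0.04 log units; within the scatter) is set at none beyond the scatter. For compound 3 the value in this assay is estimated at 80000 nM, within 30000 nM to 200000 nM.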

Compound 3, half-maximal inhibitory concentration: > 100000 nM
Compound 3 gave a limit, no number; the forecaster's own chance of this, stated with the estimate: 20%; middle value at least 1.2-fold (0.09 log units) away from the limit.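

Compound 3 gives a limit of the assay, not a number: > 100000 nM in this assay. On a triple-bonded carbon, tert-butyl in place of benzyl gives an at least 1.3-fold higher number from compound 2 to compound 3 (0.14 log units; that floor lies within the scatter), so removing the six-membered aromatic ring brings no sign of stronger inhibition. The step has only a floor and no measured size because the value sits at the limit: the limit of > 100000 nM in this assay, at which 1 of the 3 values shown sits.

As far as these compounds go, how far the true step runs past that floor stays open. So does whether an amine or a carboxylic acid on the triple-bonded carbon would give a measurable number.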